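Trading a chloro for a hydroxy on compound 3

The compounds below may be only part of what the source reports. "The series", "measured", "known", "first", "only" and "open" are said of these compounds alone.

In a functional assay on MCF7 cells (Homo sapiens) for cytotoxicity, read by MTT assay, with a stated time of 72 h (on this read-out higher numbers stand for weaker inhibition and lower numbers for stronger inhibition), compound 3 `COc1ccc(/C=C2\CCC/C(=C\c3ccc(Cl)c(Cl)c3)C2=O)cc1OC` gives 4400 nM as the lowest of three numbers. Compound 1 `COc1ccc(/C=C2\CCC/C(=C\c3ccc(O)cc3)C2=O)cc1OC` at 17000 nM and compound 2 `COc1ccc(/C=C2\CCC/C(=C\c3cccc(Cl)c3Cl)C2=O)cc1OC` at 14300 nM lie within the scatter of each other. Unmeasured compound 4 `COc1ccc(/C=C2\CCC/C(=C\c3ccc(O)c(Cl)c3)C2=O)cc1OC` carries hydroxy in place of chloro on an aromatic carbon, so 3,4-dichlorophenyl becomes 3-chloro-4-hydroxyphenyl. The closest guide is a 3.9-fold lower number from compound 1 to compound 3 (0.59 log units; beyond the scatter) as 3,4-dichlorophenyl replaces 4-hydroxyphenyl, a modest step beyond the scatter, and compound 4 keeps a chloro while gaining a hydroxy, so part of that step is expected to return. The step of a 3.3-fold lower number from compound 2 to compound 3 (0.51 log units; beyond the scatter) between two dichlorophenyl groups is also modest. In this assay the estimated change is a 2.0-fold higher number from compound 3 to compound 4 (0.31 log units; beyond the scatter) toward weaker inhibition, near the edge of the scatter. Compound 4 is estimated at 9000 nM with a range from 4000 nM to 20000 nM until the measurement arrives.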

Compound 4, half-maximal inhibitory concentration: 12300 nM
Beside the measured number, compound 4's estimate is 1.4-fold (0.14 log units) below it; low and high end bracket the measured number.
By their numbers in this assay, from the lowest: compound 3; then compounds 4, 2 and 1 (each within the scatter of the next).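

With hydroxy in place of chloro para to a large group, this assay shows a 2.8-fold higher number from compound 3 to compound 4 (0.45 log units; beyond the scatter) as a real loss at this position, so the lower number of compound 3 needs this chloro and is not carried by the remaining chloro alone. That remaining chloro adds nothing readable to the hydroxy-bearing ring, with a 1.4-fold lower number from compound 1 to compound 4 (0.14 log units; within the scatter) as the measure, and the change from the 2,3-dichlorophenyl group gives a 1.2-fold lower number from compound 2 to compound 4 (0.07 log units; within the scatter) as a second step inside the scatter. Nothing here gives a reason for this pattern. From the compounds shown here alone, whether an amine or a methyl on this carbon would act like chloro or like hydroxy stays open.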